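The source may report more compounds than this note shows. Statements on the series, on what has been measured and on what is new or still open speak of the compounds shown alone.

In a functional assay on PC-3 cells (Homo sapiens) for cytotoxicity, read by MTT assay, with a stated time of 96 h (a lower number here means a stronger inhibitor, a higher number a weaker inhibitor), compound 1 `CC[C@H](N)C(=O)N[C@@H]1C(=O)N2[C@@H](CC[C@@H]1CNC(=O)NCc1ccccc1)CC[C@H]2C(=O)NC(c1ccccc1)c1ccccc1` gives > 100000 nM, which is a limit of the assay and not a number. Compound 2 `CC[C@H](N)C(=O)N[C@@H]1C(=O)N2[C@@H](CC[C@@H]1CCNC(=O)NCc1ccccc1)CC[C@H]2C(=O)NC(c1ccccc1)c1ccccc1` gives > 100000 nM in this assay, and this too is a limit. Going by the values given here, compound 1 therefore stands with its only measured neighbour at one shared reading: the limit of > 100000 nM in this assay, at which 2 of the 2 values shown sit.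

Compound 3 `CC[C@H](N)C(=O)N[C@@H]1C(=O)N2[C@@H](CC[C@@H]1CCNCc1ccccc1)CC[C@H]2C(=O)NC(c1ccccc1)c1ccccc1` keeps the core of compound 1 and carries one change, ((benzylamino)methyl in place of (benzylcarbamoyl)amino on a saturated chain carbon bound to a saturated ring carbon). Cut one bond further out, the same difference reads ((benzylcarbamoyl)amino)methyl to 2-(benzylamino)ethyl. Among the compounds with values here, the one measured step that bears on this is a step that the two limits leave unreadable from compound 1 to compound 2. It offers no size to carry over, so the data give no measured effect of either the longer chain or the other part of the change.

The expectation is therefore cautious: compound 3 should remain a weak inhibitor in this assay, and any shift should be toward stronger inhibition, since the reading for compound 1 is a limit. The expected change is an at least 1.2-fold lower number from compound 1 to compound 3 (0.09 log units; that floor lies within the scatter). Compound 3 is estimated at 80000 nM, with an expected range from 25000 nM to 150000 nM.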

Compound 3, half-maximal inhibitory concentration: 39200 nM
The estimate for compound 3 lay 2.0-fold (0.31 log units) above the measured number; low and high end bracket the measured number.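

In this assay, going by these compounds alone, compound 3 is the only one of the three compounds that gives a number rather than a limit, at 39200 nM, which shows that the reading does respond to a change on the saturated chain carbon bound to a saturated ring carbon. The change of (benzylcarbamoyl)amino to (benzylamino)methyl gives an at least 2.5-fold lower number from compound 1 to compound 3 (0.40 log units; beyond the scatter), and benzyl in place of benzylcarbamoyl on an amine nitrogen gives an at least 2.5-fold lower number from compound 2 to compound 3 (0.40 log units; beyond the scatter). The second step keeps the chain of compound 2 and changes only the group on that nitrogen, so the loss of the benzylcarbamoyl group alone is enough to set compound 3 apart from the other two compounds, which share one reading: the limit of > 100000 nM in this assay, at which 2 of the 3 values shown sit.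

On these data alone, both steps start from a limit, so their full size stays open, and the step between the two compounds at the limit cannot be read, which leaves the effect of chain length on its own unknown. Also open, as far as these compounds go, is whether a methyl group or a phenethyl group in place of benzyl on the amine nitrogen would strengthen or weaken the reading of compound 3.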